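The compounds below may be only part of what the source reports. "The series", "measured", "known", "first", "only" and "open" are said of these compounds alone.

Of the compounds shown here, three built on a shared core have been tested in a functional assay on MCF7 cells (Homo sapiens) for antiproliferative activity, read by MTT assay, with a stated time of 72 h; a higher number here means a weaker inhibitor, a lower number a stronger inhibitor. Compound 1 `CCCSc1nc(N/N=C(\C)c2ccccc2O)c2nnn(Cc3ccccc3Cl)c2n1` gives only a limit of the assay, > 64000 nM, and not a number. That limit is the limit of > 64000 nM in this assay, at which 1 of the 3 values shown sits. Compound 3 `CCCSc1nc(N/N=C(\C)c2ccccc2O)c2nnn(Cc3ccc(O)cc3)c2n1` gives 9520 nM, and compound 2 `C#CCSc1nc(N/N=C(\C)c2ccccc2O)c2nnn(Cc3ccccc3)c2n1` gives 11300 nM. Within the data shown here, the single measured step, an at least 6.7-fold lower number from compound 1 to compound 3 (0.82 log units; beyond the scatter), concerns the group on the carbon bound to the aromatic nitrogen, not the sulfur side of the core. Among the two plain numbers, compound 2 stands highest, with compound 3 nearest to it; that gap lies within the scatter, so the two cannot be ordered.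

Compound 4 `C/C(=N\Nc1nc(SCc2ccccc2)nc2c1nnn2Cc1ccccc1)c1ccccc1O` differs from compound 2 by phenyl in place of ethynyl on a saturated chain carbon bound to a sulfur. Among the measured compounds shown here, no measured step touches the carbon bound to sulfur; the only step, from compound 1 to compound 3, changes a different group, and it gives no guidance on the direction of this change. For compound 4 the expected step is therefore a 1.1-fold lower number from compound 2 to compound 4 (0.05 log units; within the scatter), a change not expected to reach beyond the scatter in either direction. The estimate for compound 4 in this assay is 10000 nM, with a plausible span from 3500 nM to 30000 nM.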

Compound 4, half-maximal inhibitory concentration: 950 nM
Estimate against measurement, compound 4: 11-fold (1.02 log units) above; the whole stated range lies above it.
By their numbers in this assay, from the lowest: compound 4; then compounds 3 and 2 (each within the scatter of the next). At a limit, above all of these: compound 1.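

Among these compounds, the sulfur side of the core, which the only earlier step left untouched, now proves able to move the result: with phenyl in place of ethynyl on the saturated chain carbon bound to a sulfur, this assay shows a 12-fold lower number from compound 2 to compound 4 (1.08 log units; beyond the scatter). The change removes a triple bond and brings in a six-membered aromatic ring of carbon only, while neither group carries a hydrogen-bond donor or acceptor, so the shared core now has one step beyond the scatter on its sulfur side and one on the side of the saturated chain carbon bound to an aromatic nitrogen. Nothing measured among these compounds says why phenyl at this place gives the lower number.

This single step cannot show whether an aromatic ring is what counts here, and a cyclohexyl group, a pyridine ring or a longer chain ending in phenyl at the same place would help to separate that. On these data alone, it is also open whether benzylsulfanyl gives a similar step when combined with the 4-hydroxyphenyl or 2-chlorophenyl group on the other side of the core.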